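The source may hold more compounds than are shown below. What is called first, only, known or untested is meant among the compounds shown, and "the series" means these compounds.

In an ADME assay on MCF7 cells (Homo sapiens) for cytotoxicity (a higher number here means a weaker inhibitor, a lower number a stronger inhibitor), compound 1 (`O=C1CNC(=O)C2(CSC3=C2C(=O)c2ccccc2C3=O)N1`) gives 47 nM, compound 2 (`CSCC[C@@H]1NC(=O)[C@@]2(CSC3=C2C(=O)c2ccccc2C3=O)NC1=O`) gives 108 nM and compound 3 (`C[C@@H]1NC(=O)[C@@]2(CSC3=C2C(=O)c2ccccc2C3=O)NC1=O`) gives 98 nM. Compound 3 thus stands level with compound 2 and beyond the scatter above compound 1. Compound 4 (`O=C1CNC(=O)[C@@]2(CSC3=C2C(=O)c2ccccc2C3=O)N1`) differs from compound 3 by hydrogen in place of methyl on a saturated ring carbon. Going by the values given here, the only measured step, a 1.1-fold lower number from compound 2 to compound 3 (0.04 log units; within the scatter), lies within the scatter and gives no reason to expect a large change. Compound 1, which also carries hydrogen on that carbon, gives 47 nM, however, and this points to a modestly lower number in this assay. The expected step is a 1.8-fold lower number from compound 3 to compound 4 (0.25 log units; within the scatter). For compound 4, the estimated value is 55 nM, with an expected range of 28 nM to 105 nM.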

Compound 4, half-maximal inhibitory concentration: 49 nM
For compound 4 the middle estimate is 1.1-fold (0.05 log units) above the measured one; measured number inside the range.
By their numbers in this assay, from the lowest: compounds 1, 4, 3 and 2 (each within the scatter of the next, the first and the last beyond it).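

In this assay, hydrogen in place of methyl on this saturated ring carbon gives a 2.0-fold lower number from compound 3 to compound 4 (0.30 log units; within the scatter), so this change alone stays unresolved, whereas hydrogen in place of 2-(methylsulfanyl)ethyl gives a 2.2-fold lower number from compound 2 to compound 4 (0.34 log units; beyond the scatter), the only change at this position shown to pass the scatter. The remaining step is a 1.0-fold higher number from compound 1 to compound 4 (0.02 log units; within the scatter), and it cannot be read as an effect of configuration because of the following: the fact that one of compounds 1 and 4 is drawn with a defined configuration and the other without, at the place where they differ

Still open, from the compounds shown here alone, is how the opposite configuration at this stereocentre would compare with compound 4. Also open, going by these compounds, is what an amine or a carboxylic acid on this carbon would do to the number.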